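The source may report more compounds than this note shows. Statements on the series, on what has been measured and on what is new or still open speak of the compounds shown alone.

Compound 1 `CC(Sc1nnc(-c2ccncc2)s1)C(=O)Nc1ccccc1` opens the series, and in an ADME assay on HepG2 cells (Homo sapiens) for cytotoxicity, with a stated time of 3 days (on this read-out higher numbers stand for lower toxicity in this test and lower numbers for higher toxicity in this test), compound 1 gives > 50000 nM, a limit of the assay rather than a number. A companion, compound 2 `O=C(CSc1nnc(-c2ccncc2)s1)NCc1ccccc1Cl`, was also run, and in this assay compound 2 shows "not determined" (no result reported). For the measured compounds named here, the only firm evidence in this assay is therefore (the limit of > 50000 nM in this assay, at which 1 of the 2 values shown sits), and compound 1 stands at it. Compound 3 `CC(Sc1nnc(-c2ccncc2)s1)C(=O)Nc1ccc(Cl)cc1` arises from compound 1 through one change, (chloro in place of hydrogen on an aromatic carbon). Going by the values given here, no measured pair in this set shows what such a change does here, so nothing can be read from a comparison. Across this step the account expects no shift beyond the usual scatter of this assay. Compound 3 is accordingly estimated at 50000 nM, with a range from 20000 nM to 120000 nM. The expected step is a number no higher from compound 1 to compound 3 (the limit leaves the size open). Whether the measurement of compound 3 again stops at the limit remains to be seen.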

Compound 3, half-maximal cytotoxic concentration: > 50000 nM
Compound 3 ended at the assay's limit (the forecaster's own chance of this, stated with the estimate: 70%); the middle value lies on the limit itself.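

For the compounds shown here, compound 1 and compound 3 both end at a limit of the assay rather than at a number, so no step between them can be read in this assay. The compounds shown leave open what chloro in place of hydrogen does to cytotoxicity in these cells.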